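Moving the Trifluoromethyl Group on Compound 2

The source may report more compounds than this note shows. Statements on the series, on what has been measured and on what is new or still open speak of the compounds shown alone.

In a functional assay on DU-145 cells (Homo sapiens) for antiproliferative activity, read by propidium iodide staining, with a stated time of 96 h (a higher number here means a weaker inhibitor, a lower number a stronger inhibitor), compound 1 `CC(O)(CSc1ccc(C(F)(F)F)cc1)C(=O)Nc1ccc(S(F)(F)(F)(F)F)cc1` gives 28800 nM, while compound 2 `CC1(C)C(=O)N(c2ccc(S(F)(F)(F)(F)F)cc2)C(=S)N1c1ccc(C(F)(F)F)cc1` is the weaker of the two at 100000 nM. Compound 3 `CC1(C)C(=O)N(c2ccc(S(F)(F)(F)(F)F)cc2)C(=S)N1c1cccc(C(F)(F)F)c1` carries 3-(trifluoromethyl)phenyl in place of 4-(trifluoromethyl)phenyl on an amide-type nitrogen in a ring. For the measured compounds named here, no measured pair yet shows what such a move does. Going by the values given here, with compound 2 at 100000 nM, the higher value so far, a small fall in this assay near the edge of the scatter is expected, an estimated 2.0-fold lower number from compound 2 to compound 3 (0.30 log units; within the scatter). The estimate for compound 3 is 50000 nM, with an expected range of 15000 nM to 100000 nM.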

Compound 3, half-maximal inhibitory concentration: 100000 nM
Estimate against measurement, compound 3: 2.0-fold (0.30 log units) below; low and high end bracket the measured number.
By their numbers in this assay, from the lowest: compound 1; then compounds 2 and 3 (each within the scatter of the next).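

Exchanging 4-(trifluoromethyl)phenyl for 3-(trifluoromethyl)phenyl on the amide-type nitrogen in a ring gives no change at the digits printed from compound 2 to compound 3 (within the scatter) in this assay. For the compounds shown here, this is the first measured step at this position, and it shows that this change of attachment, with the same atoms, leaves the number where it stood. Nothing measured here explains this result.

The compounds shown leave open whether a nitrile or an amine in place of the trifluoromethyl group would change the number. They also leave open whether this move would have any effect on the core of compound 1.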